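Rearranging the acid-bearing ring of a prostaglandin D2 antagonist

The compounds below may be only part of what the source reports. "The series", "measured", "known", "first", "only" and "open" are said of these compounds alone.

Measured compounds:
compound 1 `CN1C[C@@H](COc2ccc(C(=O)Nc3cccc(CC(=O)O)c3)c(Cl)c2)Oc2ccccc21`, 20 nM
compound 2 `Cc1cc(OC[C@@H]2CN(C)c3ccccc3O2)ccc1C(=O)Nc1cc(CC(=O)O)ccc1Cl`, "not determined" (no result reported)
compound 3 `Cc1ccc(CC(=O)O)cc1NC(=O)c1ccc(OC[C@@H]2CN(C)c3ccccc3O2)cc1Cl`, 6 nM

Going by the values given here, in a functional assay on CHO cells for antagonist activity at prostaglandin D2 receptor (Mus musculus), read by cAMP accumulation (a higher number here means a weaker inhibitor, a lower number a stronger inhibitor), compound 3 gives the lowest number of the two reported; its nearest neighbour is compound 1, and the only one-place step, a 3.3-fold lower number from compound 1 to compound 3 (0.52 log units; beyond the scatter), is a modest one. Compound 4 `Cc1cc(CC(=O)O)cc(NC(=O)c2ccc(OC[C@@H]3CN(C)c4ccccc4O3)cc2Cl)c1` differs from compound 3 by 3-(carboxymethyl)-5-methylphenyl in place of 5-(carboxymethyl)-2-methylphenyl on an amide-type nitrogen, the two having the same atoms joined differently. Among the compounds with values here, no measured step bears directly on this rearrangement; the one step known concerns a methyl added, not the acid-bearing ring reshuffled. Compound 4 is therefore estimated at 30 nM in this assay, within 6 nM to 200 nM, which means an expected step of a 5.0-fold higher number from compound 3 to compound 4 (0.70 log units; beyond the scatter).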

Compound 4, half-maximal inhibitory concentration: 5.4 nM
Compound 4: the middle estimate sits 5.6-fold (0.74 log units) above what was measured; the measured number lies below the stated range.
By their numbers in this assay, from the lowest: compounds 4 and 3 (each within the scatter of the next); then compound 1.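

In this assay, 3-(carboxymethyl)-5-methylphenyl in place of 5-(carboxymethyl)-2-methylphenyl on an amide-type nitrogen gives a 1.1-fold lower number from compound 3 to compound 4 (0.05 log units; within the scatter), so this assay does not separate the two arrangements. The methyl also keeps its worth in the new arrangement: a 3.7-fold lower number from compound 1 to compound 4 (0.57 log units; beyond the scatter) is a modest step, as is a 3.3-fold lower number from compound 1 to compound 3 (0.52 log units; beyond the scatter), so the earlier gain was not tied to a single placing. No evidence is available to explain this tolerance. Still open, going by these compounds, is whether ethyl or methoxy in place of that methyl would hold the number, and whether a longer chain carrying the carboxylic acid would.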